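The source may report more compounds than this note shows. Statements on the series, on what has been measured and on what is new or still open speak of the compounds shown alone.

Measured compounds:
compound 1, `COc1cc(O)c(C(C)=O)cc1Br`, 41800000 nM
compound 2, `CCOc1cc(OC)c(Br)cc1C(C)=O`, 46800000 nM
compound 3, `CCCCCCOc1cc(OC)c(Br)cc1C(C)=O`, 42400000 nM

These three values come from a functional assay, with a stated time of 30 min; on this read-out higher numbers stand for weaker inhibition and lower numbers for stronger inhibition. Compound 3 stands second highest of the three numbers, with compound 1 nearest and compound 2 furthest, and both steps of a 1.0-fold higher number from compound 1 to compound 3 (0.01 log units; within the scatter) and a 1.1-fold lower number from compound 2 to compound 3 (0.04 log units; within the scatter) lie within the scatter. Compound 4, `CCCCCCCCCCOc1cc(OC)c(Br)cc1C(C)=O`, differs from compound 3 by butyl in place of hydrogen on a saturated chain carbon, six bonds along the chain from an oxygen on an aromatic ring. The step that bears most on this change is a 1.1-fold lower number from compound 2 to compound 3 (0.04 log units; within the scatter), itself a butyl in place of hydrogen on a saturated chain carbon, and the chain extensions a 1.1-fold higher number from compound 1 to compound 2 (0.05 log units; within the scatter) and a 1.0-fold higher number from compound 1 to compound 3 (0.01 log units; within the scatter) were likewise within the scatter. No step beyond the scatter is therefore expected in this assay: the estimated step is a 1.0-fold higher number from compound 3 to compound 4 (0.01 log units; within the scatter). Compound 4 is expected to give 43000000 nM, in the range 25000000 nM to 75000000 nM.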

Compound 4, half-maximal inhibitory concentration: 35100000 nM
Compound 4: middle estimate off by 1.2-fold (0.09 log units), on the high side; low and high end bracket the measured number.
By their numbers in this assay, from the lowest: compounds 4, 1, 3 and 2 (each within the scatter of the next).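

In this assay the butyl six bonds along the chain from an oxygen on an aromatic ring gives a 1.2-fold lower number from compound 3 to compound 4 (0.08 log units; within the scatter) and so adds a second butyl extension without a step beyond the scatter. The earlier extension gave a 1.1-fold lower number from compound 2 to compound 3 (0.04 log units; within the scatter) and stopped closer to that oxygen, so this result carries the same picture further out along the chain. Nothing measured here offers an explanation for this result. On these data alone, whether an amine, a carboxylic acid or a still longer chain in this place would give a step beyond the scatter stays open.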